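From Methoxy to Chloro on the Shared Core

The compounds below may be only part of what the source reports. "The series", "measured", "known", "first", "only" and "open" are said of these compounds alone.

Measured in a functional assay on MCF7 cells (Homo sapiens) for antiproliferative activity, read by MTT assay, with a stated time of 48 h, in the presence of a further agent that is not named here; a lower number here means a stronger inhibitor of growth, a higher number a weaker inhibitor of growth:
compound 1 `O=C(NOCc1ccccc1F)c1cn(-c2ccccc2)nc1-c1ccccc1` gives 16100 nM
compound 2 `Cc1ccc(-c2nn(-c3ccccc3)cc2C(=O)NOCc2ccccc2F)cc1` gives 2110 nM
compound 3 `COc1ccc(-c2nn(-c3ccccc3)cc2C(=O)NOCc2ccccc2F)cc1` gives 6000 nM

Compound 3 stands second highest of these three numbers. The step of a 2.7-fold lower number from compound 1 to compound 3 (0.43 log units; beyond the scatter) separates it from the higher number, and the step of a 2.8-fold higher number from compound 2 to compound 3 (0.45 log units; beyond the scatter) separates it from the lower one; both gaps are beyond the scatter. So compound 3 is a clearly stronger inhibitor of growth than compound 1, and a clearly weaker one than compound 2.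

Compound 4 `O=C(NOCc1ccccc1F)c1cn(-c2ccccc2)nc1-c1ccc(Cl)cc1` differs from compound 3 in one place: chloro in place of methoxy on an aromatic carbon. Among the measured compounds shown here, no measured step involves chloro, so the expectation rests on the two groups already tried at this place. Putting methyl there lowered the number (a 7.6-fold lower number from compound 1 to compound 2 (0.88 log units; beyond the scatter)), and putting methoxy there also lowered it, though less (a 2.7-fold lower number from compound 1 to compound 3 (0.43 log units; beyond the scatter)); swapping methyl for methoxy raised it (a 2.8-fold higher number from compound 2 to compound 3 (0.45 log units; beyond the scatter)). A group at this place has so far always helped, with methyl helping more than methoxy. Chloro is expected to land near the methyl result, giving an estimated step of a 2.0-fold lower number from compound 3 to compound 4 (0.30 log units; within the scatter), modest and just beyond the scatter. Compound 4 is therefore expected to give about 3000 nM, within a range from 1000 nM to 9000 nM.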

Compound 4, concentration for 50% growth inhibition: 15100 nM
For compound 4 the middle estimate is 5.0-fold (0.70 log units) below the measured one, and the stated range ends below it.
By their numbers in this assay, from the lowest: compound 2; then compound 3; then compounds 4 and 1 (each within the scatter of the next).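

In this assay, a group at this place does not lower the number simply by being there: chloro in place of hydrogen gives (a 1.1-fold lower number from compound 1 to compound 4 (0.03 log units; within the scatter)), so compound 4 cannot be told apart from compound 1, whereas methyl and methoxy both moved the number clearly down. What counts is which group sits on the ring, and the change to chloro gives up the gain seen with either of the other two groups, by a smaller step from methoxy (a 2.5-fold higher number from compound 3 to compound 4 (0.40 log units; beyond the scatter)) and a larger one from methyl (a 7.2-fold higher number from compound 2 to compound 4 (0.85 log units; beyond the scatter)). Among these compounds, then, 4-chlorophenyl behaves like plain phenyl and not like 4-methoxyphenyl or the methyl-bearing ring, and nothing available explains that difference.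

On these data alone, three groups and hydrogen are too few to show what separates a helpful group from an unhelpful one, so it remains open whether an amine, a carboxylic acid, a fluoro group or a longer chain such as ethyl would follow methyl or chloro at this place. As far as these compounds go, it also remains open whether the same order of groups would hold if the shared core were changed elsewhere.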